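From iodo to 4-methylphenyl: what size of step?

This account rests on a few compounds, and the source may have more. Where it says the series, first, only, none or still open, it means among the compounds named here.

Measured so far in a functional assay on AGS cells (Homo sapiens) for inhibition, read by reporter gene assay (on this read-out higher numbers stand for weaker inhibition and lower numbers for stronger inhibition), are three compounds
Compound 1 `CC(C)(C)c1ccc(OCC(=O)Nc2cccc(C(=O)O)c2)cc1` gives 9500 nM
Compound 2 `O=C(COc1ccc(Br)cc1)Nc1cccc(C(=O)O)c1` gives 1600 nM
Compound 3 `O=C(COc1ccc(I)cc1)Nc1cccc(C(=O)O)c1` gives 3500 nM

Compound 3 holds the middle place among these three numbers. Its two measured steps are a 2.2-fold higher number from compound 2 to compound 3 (0.34 log units; beyond the scatter) and a 2.7-fold lower number from compound 1 to compound 3 (0.43 log units; beyond the scatter), and both are modest. Compound 4 `Cc1ccc(-c2ccc(OCC(=O)Nc3cccc(C(=O)O)c3)cc2)cc1` has not been measured. The change is 4-methylphenyl in place of iodo on an aromatic carbon, which puts 4-methylphenyl in place of iodo on an aromatic carbon, para to a large group. In this assay, among the measured compounds shown here, the number rises from bromo through iodo to tert-butyl, but no measured compound carries an aryl group here, so the guide is weak. A modest step toward a higher number is expected, and no more than that. The expected step is a 1.7-fold higher number from compound 3 to compound 4 (0.23 log units; within the scatter) in size. For compound 4 the estimated value is 6000 nM, with an expected range from 1500 nM to 20000 nM as its bounds.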

Compound 4, half-maximal inhibitory concentration: > 30000 nM
Compound 4: a limit, no number; the forecaster's own chance of this, stated with the estimate: 10%; middle value at least 5.0-fold (0.69 log units) from the limit.
By their numbers in this assay, from the lowest: compound 2; then compound 3; then compound 1. At a limit, above all of these: compound 4.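

Compound 4 gives no number, only a limit: the limit of > 30000 nM in this assay, at which 1 of the 4 values shown sits. Measured against iodo there is an at least 8.5-fold higher number from compound 3 to compound 4 (0.93 log units; beyond the scatter), against bromo an at least 18-fold higher number from compound 2 to compound 4 (1.27 log units; beyond the scatter), and against tert-butyl an at least 3.1-fold higher number from compound 1 to compound 4 (0.49 log units; beyond the scatter). This aromatic carbon thus carries bromo, iodo and tert-butyl with measurable numbers, but 4-methylphenyl, with its added six-membered aromatic ring, gives none.

The compounds shown leave open whether the loss comes with the ring itself or with its methyl, which a plain phenyl would separate. They also leave open how chloro or methoxy would fare at this carbon.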